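The source may hold more compounds than are shown below. What is called first, only, known or untested is meant among the compounds shown, and "the series" means these compounds.

Measured compounds:
- compound 1, `COc1ccc2c(=O)c(/C=C/C(=O)NCc3ccc(C)cc3)coc2c1`; in a functional assay on A549 cells (Homo sapiens) for inhibition, read by MTT assay, with a stated time of 48 h (on this read-out lower numbers stand for stronger inhibition and higher numbers for weaker inhibition), compound 1 gives > 100000 nM, a limit of the assay.
- compound 2, `COc1ccc2c(=O)c(/C=C/C(=O)Nc3ccccc3OC)coc2c1`; in this assay compound 2 gives > 100000 nM, again a limit.
- compound 3, `COc1ccc2c(=O)c(/C=C/C(=O)Nc3cccc(C)c3)coc2c1`; in this assay compound 3 gives > 100000 nM, also a limit.

Compound 3 therefore stands nowhere on a numerical scale: only a limit is known for it, and the same holds for the two other amides, so that (the limit of > 100000 nM in this assay, at which 3 of the 3 values shown sit). The steps a step that the two limits leave unreadable from compound 1 to compound 2, a step that the two limits leave unreadable from compound 1 to compound 3 and a step that the two limits leave unreadable from compound 2 to compound 3 are all unreadable in size, since both ends of each sit at the limit.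

Compound 4, `COc1ccc2c(=O)c(/C=C/C(=O)Nc3ccccc3Cl)coc2c1`, is not yet measured. It differs from compound 3 by 2-chlorophenyl in place of 3-methylphenyl on an amide-type nitrogen. Among the measured compounds shown here, the only comparisons that bear on this change are the three unreadable steps above; none gives a direction or a size. What they show is that three different aryl or benzyl groups on the amide nitrogen all leave the compound at the limit, and compound 4 is expected to do the same. The estimated step of a number no higher from compound 3 to compound 4 (the limit leaves the size open) is expected to stay within the scatter. For compound 4 the estimate in this assay is 100000 nM, with a range from 30000 nM to 300000 nM, most likely reported again as a limit.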

Compound 4, half-maximal inhibitory concentration: 29900 nM
Compound 4: the middle estimate sits 3.3-fold (0.52 log units) above what was measured, and the stated range ends above it.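

In this assay, among the compounds shown here, 2-chlorophenyl in place of 3-methylphenyl on the amide-type nitrogen gives the first step with a readable lower bound: an at least 3.3-fold lower number from compound 3 to compound 4 (0.52 log units; beyond the scatter). Chloro in place of methoxy on an aromatic carbon gives an at least 3.3-fold lower number from compound 2 to compound 4 (0.52 log units; beyond the scatter), and 2-chlorophenyl in place of 4-methylbenzyl gives an at least 3.3-fold lower number from compound 1 to compound 4 (0.52 log units; beyond the scatter), so the group on this nitrogen can bring a compound off the limit. Compound 1, compound 2 and compound 3 remain limits, which leaves the full size of all three steps open and the steps among these three compounds unreadable: the limit of > 100000 nM in this assay, at which 3 of the 4 values shown sit.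

On these data alone, how far the effect depends on chloro itself, or on where it sits on the phenyl ring, stays open. A 2-bromophenyl, 3-chlorophenyl or 2-aminophenyl group on the same nitrogen would bear on this.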